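A few compounds are considered here, and "the series" means these few. Any claim that something is new, unique, unknown or untested is made for them only; others in the source may bear on it.

In a functional assay on HeLa cells (Homo sapiens) for antiproliferative activity, read by WST assay, with a stated time of 24 h (on this read-out lower numbers stand for stronger inhibition and higher numbers for weaker inhibition), compound 1 `C=C[C@]1(C)CC[C@@H](C(=C)CNC(C)(C)C)C[C@H]1C(=C)C` gives 25400 nM, which places it close to one of its two measured relatives and well apart from the other. Compound 3 `C=C[C@]1(C)CC[C@@H](C(=C)Cn2ccnc2)C[C@H]1C(=C)C` gives 15700 nM, and the comparison shows a 1.6-fold lower number from compound 1 to compound 3 (0.21 log units; within the scatter). Compound 2 `C=C[C@]1(C)CC[C@@H](C(=C)COCC)C[C@H]1C(=C)C` gives 106000 nM, with a 4.2-fold higher number from compound 1 to compound 2 (0.62 log units; beyond the scatter). The remaining comparison shows a 6.8-fold lower number from compound 2 to compound 3 (0.83 log units; beyond the scatter).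

Compound 4 `C=C[C@]1(C)CC[C@@H](C(=C)CNC2CCCCCCC2)C[C@H]1C(=C)C` keeps the core of compound 1 and changes one group: cyclooctyl in place of tert-butyl on an amine nitrogen. The change is cyclooctyl in place of tert-butyl on an amine nitrogen. Going by the values given here, no measured compound varies the group on that nitrogen, so the data offer no direct precedent and no firm direction. The three measured steps bear on it only indirectly, since each replaces the whole substituent on the saturated chain carbon. Even so, these larger replacements reach only modest size, as in a 4.2-fold higher number from compound 1 to compound 2 (0.62 log units; beyond the scatter), and one stays as small as a 1.6-fold lower number from compound 1 to compound 3 (0.21 log units; within the scatter). A change that leaves the amine nitrogen in place is therefore expected to produce no step beyond the scatter in this assay. The expected step is a 1.4-fold lower number from compound 1 to compound 4 (0.15 log units; within the scatter). Compound 4 is estimated at 18000 nM, with an expected range from 7000 nM to 45000 nM.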

Compound 4, half-maximal inhibitory concentration: 5900 nM
For compound 4 the middle estimate is 3.1-fold (0.48 log units) above the measured one; measured number outside the range, below it.
By their numbers in this assay, from the lowest: compound 4; then compounds 3 and 1 (each within the scatter of the next); then compound 2.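

In this assay, the group on the amine nitrogen turns out to matter: cyclooctyl in place of tert-butyl gives a 4.3-fold lower number from compound 1 to compound 4 (0.63 log units; beyond the scatter). The earlier steps shown here each replaced the whole substituent on the saturated chain carbon and said nothing about this nitrogen, yet this change, which leaves the nitrogen in place, moves the number by about as much as the modest 4.2-fold higher number from compound 1 to compound 2 (0.62 log units; beyond the scatter), though in the opposite direction. No evidence is available on what lies behind the lower number of compound 4.

The compounds shown do not separate the eight-membered ring from the larger carbon count, since cyclooctyl differs from tert-butyl in both; a straight octyl chain or a cyclohexyl ring on the same nitrogen would bear on that question. Going by these compounds, it also remains open whether the trend continues with other groups on this nitrogen, such as a benzyl group, or whether a methyl group added to the nitrogen of compound 4, giving a tertiary amine, would keep the lower number.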